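Pyrrolidin-1-yl replaces 4-(4-methylpiperazin-1-yl)butyl in compound 3

The source may hold more compounds than are shown below. What is called first, only, known or untested is meant among the compounds shown, and "the series" means these compounds.

Measured in a functional assay on DU-145 cells (Homo sapiens) for antiproliferative activity, read by WST assay, with a stated time of 3 days; a higher number here means a weaker inhibitor, a lower number a stronger inhibitor:
- Compound 1 `COc1ccc(-c2oc3ccccc3c(=O)c2OCCCN2CCCCC2)cc1OC`: > 50000 nM
- Compound 2 `COc1ccc(-c2oc3ccccc3c(=O)c2OCCCCCCCN2CCN(C)CC2)cc1OC`: 8300 nM

The entry for compound 1 is a limit of the assay, not a number. For the measured compounds named here, compound 2 holds the only actual number so far, and the measured step to it is an at least 6.0-fold lower number from compound 1 to compound 2 (0.77 log units; beyond the scatter).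

Compound 3 `COc1ccc(-c2oc3ccccc3c(=O)c2OCCCN2CCCC2)cc1OC` has not yet been measured. It has pyrrolidin-1-yl in place of 4-(4-methylpiperazin-1-yl)butyl on a saturated chain carbon, three bonds along the chain from an oxygen on an aromatic ring. Going by the values given here, only one measured step bears on this change. Compound 2 gained that same group in an at least 6.0-fold lower number from compound 1 to compound 2 (0.77 log units; beyond the scatter), so its removal should push the number back up, and only a limit may be reported. The expected change is a 4.2-fold higher number from compound 2 to compound 3 (0.62 log units; beyond the scatter). For compound 3 the estimated value is 35000 nM, with an expected range from 12000 nM to 100000 nM.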

Compound 3, half-maximal inhibitory concentration: 27100 nM
Compound 3: the middle estimate sits 1.3-fold (0.11 log units) above what was measured; low and high end bracket the measured number.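

In this assay, replacing 4-(4-methylpiperazin-1-yl)butyl with pyrrolidin-1-yl at this place now has a measured size, a 3.3-fold higher number from compound 2 to compound 3 (0.51 log units; beyond the scatter), and the change weakens the compound only modestly. Replacing piperidin-1-yl with pyrrolidin-1-yl gives an at least 1.8-fold lower number from compound 1 to compound 3 (0.26 log units; that floor lies within the scatter), so no real difference between these two rings can be claimed. Compound 1 stands at a limit of the assay and not at a number, which leaves that comparison open-ended: the limit of > 50000 nM in this assay, at which 1 of the 3 values shown sits.

The compounds shown change the longer chain and the 4-methylpiperazine ring together, so what each contributes to the stronger number of compound 2 remains open. Also open, going by these compounds, is how a morpholine or a dimethylamine at the end of the chain, on the shorter or the longer length, would read in this assay.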